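Swapping a methyl for hydrogen on an aromatic nitrogen

This account rests on a few compounds, and the source may have more. Where it says the series, first, only, none or still open, it means among the compounds named here.

- compound 1 `COc1ccc2c(/C=C/C(=O)c3cc(N)c(OC)c(OC)c3)c[nH]c2c1` gives 368 nM
- compound 2 `COc1cc(C(=O)/C=C/c2cn(C)c3ccccc23)cc(N)c1OC` gives 605 nM

In a functional assay on HCT-8 cells (Homo sapiens) for antiproliferative activity, read by MTT assay, with a stated time of 48 h (on this read-out lower numbers stand for stronger inhibition and higher numbers for weaker inhibition), compound 2 (605 nM) sits within the usual scatter of compound 1 (368 nM), so these two cannot be ranked. The next compound, compound 3 (`COc1cc(C(=O)/C=C/c2c[nH]c3ccccc23)cc(N)c1OC`), differs from compound 2 in one place: hydrogen in place of methyl on an aromatic nitrogen. Going by the values given here, no measured pair shows this change alone. Compound 1 also has hydrogen on such a nitrogen, but it differs from compound 2 in more than one place, so it is only a loose guide. With compound 1 (368 nM) as that guide, a small lowering of the number, not beyond the scatter, is expected in this assay for this change. The estimate amounts to a 1.3-fold lower number from compound 2 to compound 3 (0.13 log units; within the scatter) as the expected step. For compound 3 the expected value is 450 nM (estimated range 150 nM to 1400 nM).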

Compound 3, half-maximal inhibitory concentration: 577 nM
Compound 3: the middle estimate sits 1.3-fold (0.11 log units) below what was measured; the range from low to high includes it.
By their numbers in this assay, from the lowest: compounds 1, 3 and 2 (each within the scatter of the next).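

In this assay, the pair that isolates this change gives a 1.0-fold lower number from compound 2 to compound 3 (0.02 log units; within the scatter), so hydrogen and methyl on this aromatic nitrogen cannot be told apart here. Compound 3 also connects to compound 1 through a different single change, hydrogen in place of methoxy on an aromatic carbon, which gives a 1.6-fold higher number from compound 1 to compound 3 (0.20 log units; within the scatter). Neither single change separates its pair in this assay, and all three compounds remain unranked.

Going by these compounds, whether a larger group on that nitrogen, such as benzyl or a longer chain, would also stay within the scatter remains open, as does the effect of an amine or a carboxylic acid there. Nothing available explains why these pairs fall so close together.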